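Amine swap on the shared core: compound 2 to compound 4

A few compounds are considered here, and "the series" means these few. Any claim that something is new, unique, unknown or untested is made for them only; others in the source may bear on it.

Compound 1 `CCN(c1nc(C)nc(N(CC2CC2)CC2CC2)n1)c1ccc(N(C)C)cc1C(F)(F)F`: 5 nM in an assay on isolated protein for binding affinity to corticotropin-releasing factor receptor 1 (Homo sapiens); on this read-out higher numbers stand for weaker inhibition and lower numbers for stronger inhibition
Compound 2 `CCCN(CC1CC1)c1nc(C)nc(N(CC)c2ccc(N(C)C)cc2C(F)(F)F)n1`: 5 nM
Compound 3 `CCN(c1ccc(C(C)C)cc1)c1nc(C)cc(C)n1`: > 1000 nM, a limit of the assay

Compound 2 stands level with compound 1 at the digits shown; the step of no change at the digits printed from compound 1 to compound 2 (within the scatter) is within the scatter, so neither is called the stronger. Compound 3 sits at the limit of > 1000 nM in this assay, at which 1 of the 3 values shown sits, and gives no number. Compound 4 `CCCCN(CC#N)c1nc(C)nc(N(CC)c2ccc(N(C)C)cc2C(F)(F)F)n1` is not yet measured. For the measured compounds named here, the change butyl(cyanomethyl)amino in place of (cyclopropylmethyl)(propyl)amino on an aromatic carbon is larger than the one measured step: the three-membered ring leaves, a nitrile enters. Going by the values given here, only the step from compound 1 to compound 2 touches this part of the core, and it was flat, which points to a small step at most. Because no change at the digits printed from compound 1 to compound 2 (within the scatter) was flat, compound 4 is expected near compound 2, with some allowance for weakening from the nitrile; the expected step is a 3.0-fold higher number from compound 2 to compound 4 (0.48 log units; beyond the scatter). Compound 4 is therefore estimated at 15 nM, in a range from 3 nM to 80 nM in this assay.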

Compound 4, inhibition constant: 6 nM
Compound 4: the middle estimate sits 2.5-fold (0.40 log units) above what was measured; the range from low to high includes it.
By their numbers in this assay, from the lowest: compounds 1, 2 and 4 (each within the scatter of the next). At a limit, above all of these: compound 3.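

In this assay, this aromatic carbon of the shared core accepts a wider change than the earlier step showed: a 1.2-fold higher number from compound 2 to compound 4 (0.08 log units; within the scatter), and a 1.2-fold higher number from compound 1 to compound 4 (0.08 log units; within the scatter). Butyl(cyanomethyl)amino therefore stands level with both (cyclopropylmethyl)(propyl)amino and bis(cyclopropylmethyl)amino, so among these compounds the three-membered ring is not needed to hold this level, and a nitrile on an open chain is accepted in its place. Nothing measured here accounts for why the value stays flat across these groups.

Going by these compounds, whether a carboxylic acid or a primary amine at the end of the chain, or a longer chain such as octyl, would hold this level remains open. So does the extent of this tolerance, as no group compared at this position moves the value beyond the scatter.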